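Methyl on the anilide ring of compound 3

A few compounds are considered here, and "the series" means these few. Any claim that something is new, unique, unknown or untested is made for them only; others in the source may bear on it.

In a functional assay on LNCaP C4-2 cells (Homo sapiens) for cytotoxicity, read by MTT assay, with a stated time of 48 h, in the presence of a further agent that is not named here (a lower number here means a stronger inhibitor, a higher number a weaker inhibitor), compound 3 `O=C(Nc1ccccc1)c1csc(-c2c[nH]c3ccccc23)n1` gives only a limit, > 100000 nM. Compound 1 `O=C(NCc1ccccc1)c1csc(-c2c[nH]c3ccccc23)n1` likewise gives only a limit, > 100000 nM. Compound 2 `O=C(Nc1ccccc1)c1csc(-c2cn(Cc3ccc(Cl)cc3)c3ccccc23)n1` also gives only a limit, > 100000 nM. All three values sit at the same limit (the limit of > 100000 nM in this assay, at which 3 of the 3 values shown sit), so the steps a step that the two limits leave unreadable from compound 1 to compound 3 and a step that the two limits leave unreadable from compound 2 to compound 3 cannot be sized, and nothing about their direction can be read.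

Compound 4 `Cc1ccc(NC(=O)c2csc(-c3c[nH]c4ccccc34)n2)cc1` differs from compound 3 by methyl in place of hydrogen on an aromatic carbon of a six-membered aromatic ring of carbon only, para to a large group; cut one bond further out, phenyl to 4-methylphenyl, anilino to (4-methylphenyl)amino. The two measured steps concern other parts of the molecule and give no readable size, so they offer no direction for this assay. The change itself is a single carbon. The expected step of a number no higher from compound 3 to compound 4 (the limit leaves the size open) is estimated to be none beyond the scatter. Compound 4 is therefore expected to give 100000 nM in this assay, with a range from 30000 nM to 300000 nM, most likely once more reported only as a limit.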

Compound 4, half-maximal inhibitory concentration: > 100000 nM
Compound 4 ended at the assay's limit (the forecaster's own chance of this, stated with the estimate: 80%); the middle value lies on the limit itself.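

In this assay compound 4 gives > 100000 nM, a limit, so its steps from compound 3 and from compound 1 cannot be read: the limit of > 100000 nM in this assay, at which 4 of the 4 values shown sit.

The compounds shown leave open whether any change to the shared core or its substituents yields a value that is not a limit.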